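A few compounds are considered here, and "the series" means these few. Any claim that something is new, unique, unknown or untested is made for them only; others in the source may bear on it.

Compound 2 `O=C(/C=C/c1ccc(Cl)c([N+](=O)[O-])c1)/C=C/c1ccccc1Oc1ncnc2ccc(Cl)cc12` gives 70.2% in a functional assay on MGC-803 cells (Homo sapiens) for inhibition, read by MTT assay, with a stated time of 72 h, tested at 10 uM (on this read-out lower numbers stand for less inhibition of growth and higher numbers for more inhibition of growth at the one concentration tested), the highest of the three numbers recorded there. Compound 1 `O=C(/C=C/c1ccc(Oc2ncnc3ccc(Cl)cc23)cc1)/C=C/c1c(Cl)cccc1Cl` gives 61.7%, which lies within the scatter of compound 2, so no order can be read between these two. Compound 3 `O=C(/C=C/c1ccc(Cl)c(Cl)c1)/C=C/c1ccccc1Oc1ncnc2ccc(Cl)cc12` gives 56.7%, and the step of a number 13.5 percentage points lower from compound 2 to compound 3 (beyond the scatter) is beyond the scatter.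

Compound 4 `O=C(/C=C/c1ccccc1Oc1ncnc2ccc(Cl)cc12)/C=C/c1c(Cl)cccc1Cl` has not yet been measured. It differs from compound 2 by 2,6-dichlorophenyl in place of 4-chloro-3-nitrophenyl on a double-bonded chain carbon bound to a double-bonded chain carbon. For the measured compounds named here, the only measured step that bears on this change is the one from compound 2 to compound 3, where a chloro took the place of a nitro on an aromatic carbon and the growth inhibition fell by a modest amount. Compound 4 also loses the nitro group, while compound 1, which already carries a 2,6-dichlorophenyl, sits within the scatter of compound 2. A modest drop is therefore expected, estimated as a number 12.2 percentage points lower from compound 2 to compound 4 (beyond the scatter). Compound 4 is expected to reach about 58%, with a range from 46% to 70%.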

Compound 4, percent growth inhibition at one concentration: 69.3%
Beside the measured number, compound 4's estimate is 11.3 percentage points below it; low and high end bracket the measured number.
By their numbers in this assay, from the lowest: compounds 3, 1, 4 and 2 (each within the scatter of the next, the first and the last beyond it).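

In this assay the change from 4-chloro-3-nitrophenyl to 2,6-dichlorophenyl on a double-bonded chain carbon bound to a double-bonded chain carbon gives a number 0.9 percentage points lower from compound 2 to compound 4 (within the scatter), so at this position a ring without the nitro group can keep the growth inhibition of the nitro compound. The two dichlorophenyl groups are not interchangeable, since 2,6-dichlorophenyl in place of 3,4-dichlorophenyl gives a number 12.6 percentage points higher from compound 3 to compound 4 (beyond the scatter), and the fall seen earlier on swapping nitro for chloro therefore does not hold for every ring lacking nitro. Nothing measured here explains the difference between these rings.

Whether chlorine is needed at all stays open, as the compounds shown include no ring at this position bearing only hydrogen, a methoxy group or an amine. On these data alone, each number also comes from a single concentration, so how the compounds compare across a range of concentrations remains unknown.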